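Benzyloxycarbonyl for tert-Butoxycarbonyl on a Dithiocarbamate Piperazine

The compounds below may be only part of what the source reports. "The series", "measured", "known", "first", "only" and "open" are said of these compounds alone.

Three compounds have been measured in a functional assay on ECa-109 cells (Homo sapiens) for inhibition, read by MTT assay, with a stated time of 72 h; on this read-out lower numbers stand for stronger inhibition and higher numbers for weaker inhibition:

Compound 1 `O=C(OCc1ccccc1)N1CCN(C(=S)SCc2cn(Cc3ccc(Cl)cc3)nn2)CC1`: > 128000 nM, a limit of this assay and not a number.
Compound 2 `CC(C)(C)OC(=O)N1CCN(C(=S)SCc2cn(Cc3ccc(Cl)cc3)nn2)CC1`: > 128000 nM, likewise a limit and not a number.
Compound 3 `CC(C)(C)OC(=O)N1CCN(C(=S)SCc2cn(Cc3ccccc3Cl)nn2)CC1`: 11900 nM.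

Going by the values given here, compound 3 therefore carries the only real number in this assay, while the other two values sit at the limit of > 128000 nM in this assay, at which 2 of the 3 values shown sit. Compound 2 differs from compound 3 in the halogenated ring, (2-chlorophenyl in place of 4-chlorophenyl on a saturated chain carbon bound to an aromatic nitrogen), and that change gives an at least 10-fold lower number from compound 2 to compound 3 (1.03 log units; beyond the scatter). Compound 2 differs from compound 1 by a change at the carbamate, (benzyl in place of tert-butyl on an oxygen next to a carbonyl group), but with both values at a limit that step is a step that the two limits leave unreadable from compound 2 to compound 1.

Compound 4 `O=C(OCc1ccccc1)N1CCN(C(=S)SCc2cn(Cc3ccccc3Cl)nn2)CC1` has not yet been measured. It stands to compound 3 as compound 1 stands to compound 2: the same change, (benzyl in place of tert-butyl on an oxygen next to a carbonyl group), made now on the core that carries the 2-chlorobenzyl group. Among the compounds with values here, the one earlier instance of this change is not readable, so nothing among the measured compounds tells in which direction it moves the number. The account rests on compound 3 alone, whose value in this assay is 11900 nM. Compound 4 is therefore expected to stay near that figure, with an expected step of a 1.0-fold higher number from compound 3 to compound 4 (0.00 log units; within the scatter). The estimate for compound 4 is 12000 nM, expected to fall between 4000 nM and 40000 nM.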

Compound 4, half-maximal inhibitory concentration: 56800 nM
Beside the measured number, compound 4's estimate is 4.7-fold (0.68 log units) below it; the whole stated range lies below it.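

In this assay, putting benzyl in place of tert-butyl on an oxygen next to a carbonyl group gives a 4.8-fold higher number from compound 3 to compound 4 (0.68 log units; beyond the scatter), but the earlier instance of that change, between compound 2 and compound 1, cannot be read, as both values there are limits of the assay and not numbers. The other change, 2-chlorophenyl in place of 4-chlorophenyl, can now be followed on both cores, where it gives an at least 2.2-fold lower number from compound 1 to compound 4 (0.35 log units; beyond the scatter) and, set beside its earlier instance, reads: the same change on two cores in this assay, an at least 10-fold lower number (1.03 log units; beyond the scatter) from compound 2 to compound 3 and an at least 2.2-fold lower number (0.35 log units; beyond the scatter) from compound 1 to compound 4; the limit leaves it open whether they differ This shows that the ring change lowers the number in the same direction on the tert-butoxycarbonyl and benzyloxycarbonyl cores, but it does not show that the size of that change carries over, nor, with a single readable instance, that the benzyl change moves the number the same way on another core.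

The compounds shown leave open how the number would move with a smaller group such as methyl or ethyl on that oxygen, or with a free amine in place of the carbamate. They also leave open how fluorine or methoxy would read in place of the chlorine on the ring of the 2-chlorophenyl group.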